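Benzyloxy in place of bromo at one aromatic carbon

The source may report more compounds than this note shows. Statements on the series, on what has been measured and on what is new or still open speak of the compounds shown alone.

Compound 1 `Fc1ccc(C2=NN(C(=S)Nc3ccccc3)C(c3ccc4c(c3)OCCO4)C2)cc1` gives 15700 nM in a functional assay on A-375 cells (Homo sapiens) for antiproliferative activity, read by MTT assay, with a stated time of 48 h; on this read-out higher numbers stand for weaker inhibition of growth and lower numbers for stronger inhibition of growth.
Compound 2 `S=C(Nc1ccccc1)N1N=C(c2ccc(Br)cc2)CC1c1ccc2c(c1)OCCO2` gives 470 nM.
Compound 3 `S=C(Nc1ccccc1)N1N=C(c2cccc(Cl)c2)CC1c1ccc2c(c1)OCCO2` reaches only a limit of this assay, > 200000 nM.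

Compound 2 holds the lowest of the two numbers shown. The change a 33-fold lower number from compound 1 to compound 2 (1.52 log units; beyond the scatter) is large, and the change an at least 420-fold higher number from compound 2 to compound 3 (2.62 log units; beyond the scatter) is larger still, though compound 3 sits at a limit (the limit of > 200000 nM in this assay, at which 1 of the 3 values shown sits).

Compound 4 `S=C(Nc1ccccc1)N1N=C(c2ccc(OCc3ccccc3)cc2)CC1c1ccc2c(c1)OCCO2` differs from compound 2 by benzyloxy in place of bromo on an aromatic carbon. Among the compounds with values here, only one measured step alters the group at this same position: replacing fluoro with bromo gave a 33-fold lower number from compound 1 to compound 2 (1.52 log units; beyond the scatter), a large gain. A far bulkier benzyloxy group is new ground, so a moderate loss with wide uncertainty is expected, a 5.3-fold higher number from compound 2 to compound 4 (0.73 log units; beyond the scatter). Compound 4 is estimated at 2500 nM, within 250 nM to 25000 nM.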

Compound 4, concentration for 50% growth inhibition: 350 nM
Beside the measured number, compound 4's estimate is 7.1-fold (0.85 log units) above it; measured number inside the range.
By their numbers in this assay, from the lowest: compounds 4 and 2 (each within the scatter of the next); then compound 1. At a limit, above all of these: compound 3.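

Swapping bromo for benzyloxy gives a 1.3-fold lower number from compound 2 to compound 4 (0.13 log units; within the scatter), so this aromatic position accepts a group of eight heavy atoms in place of a single bromine with no readable change in this assay. Fluoro now stands apart from two very different groups, with a 45-fold lower number from compound 1 to compound 4 (1.65 log units; beyond the scatter) showing that benzyloxy, like bromo, sits far from it.

On these data alone, whether an amine or a carboxylic acid at this position would keep the number this low remains open. The data shown give no reason why fluoro differs from bromo and benzyloxy.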